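From 3-chlorophenyl to 2-fluorophenyl in compound 4

The source may report more compounds than this note shows. Statements on the series, on what has been measured and on what is new or still open speak of the compounds shown alone.

Compound 1 `Cc1ccccc1NNC(=O)c1ccc(NS(=O)(=O)c2cnc(O)nc2O)cc1`: > 20000 nM (a limit of the assay, not a number)
Compound 2 `CCCCOc1ccc(C(=O)NNC(=O)c2ccc(NS(=O)(=O)c3cnc(O)nc3O)cc2)cc1`: 12800 nM
Compound 3 `O=C(NNC(=O)c1cccc(Cl)c1)c1ccc(NS(=O)(=O)c2cnc(O)nc2O)cc1`: 7710 nM

All three results come from a functional assay on OVCAR-3 cells (Homo sapiens) for antiproliferative activity, read by MTT assay, with a stated time of 24 h; a higher number here means a weaker inhibitor, a lower number a stronger inhibitor. Only compound 2 and compound 3 give actual numbers, and these two lie within the scatter of each other. Compound 3 therefore shares the best-measured position with compound 2 rather than holding it alone. Among the measured compounds shown here, the one measured step beyond the scatter is an at least 2.5-fold lower number from compound 1 to compound 3 (0.41 log units; beyond the scatter), and it exchanges the whole group on an amine nitrogen.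

Compound 4 `O=C(NNC(=O)c1ccccc1F)c1ccc(NS(=O)(=O)c2cnc(O)nc2O)cc1` has not yet been measured. It has 2-fluorophenyl in place of 3-chlorophenyl on a carbonyl carbon. The measured step that bears most directly on this change replaces 4-butoxyphenyl at the same kind of place, and it stayed small: a 1.7-fold lower number from compound 2 to compound 3 (0.22 log units; within the scatter). The step on the amine nitrogen alters more of the molecule and so bears on it less. A change beyond the scatter in this assay is therefore not expected, and the estimated step is a 1.3-fold higher number from compound 3 to compound 4 (0.11 log units; within the scatter). For compound 4 the expected value is 10000 nM, with an estimated range from 4500 nM to 20000 nM.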

Compound 4, half-maximal inhibitory concentration: 16000 nM
Beside the measured number, compound 4's estimate is 1.6-fold (0.20 log units) below it; the range from low to high includes it.
By their numbers in this assay, from the lowest: compounds 3, 2 and 4 (each within the scatter of the next, the first and the last beyond it). At a limit, above all of these: compound 1.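

At the carbonyl carbon in this assay a change of aryl group now registers: 2-fluorophenyl in place of 3-chlorophenyl gives a 2.1-fold higher number from compound 3 to compound 4 (0.32 log units; beyond the scatter) although both groups hold the same count of heavy atoms and one six-membered aromatic ring of carbon only. The same place does not separate 2-fluorophenyl from 4-butoxyphenyl, with a 1.3-fold higher number from compound 2 to compound 4 (0.10 log units; within the scatter) and so compound 2 lies within the scatter of both compound 3 and compound 4 while those two lie apart. Compound 1 stands at a limit of the assay and not at a number, and an at least 1.2-fold lower number from compound 1 to compound 4 (0.09 log units; that floor lies within the scatter) gives only a floor: the limit of > 20000 nM in this assay, at which 1 of the 4 values shown sits.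

3-chlorophenyl and 2-fluorophenyl differ both in the halogen and in where it sits, and the compounds shown leave open which of the two carries the step. From the compounds shown here alone, how 2-chlorophenyl, 3-fluorophenyl or a phenyl bearing a carboxylic acid would read at this carbonyl carbon also stays open.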